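A few compounds are considered here, and "the series" means these few. Any claim that something is new, unique, unknown or untested is made for them only; others in the source may bear on it.

Working notes on the series in a functional assay on the whole organism with Rattus norvegicus as the target, at a dose of 100 mg/kg; on this read-out lower numbers stand for less inhibition and higher numbers for more inhibition at the one dose given (going by the name of the read-out). Three compounds on the shared core carry a measured number. Compound 1 `C/N=C(/NC#N)NCCCCCCn1nc(-c2ccccc2)ccc1=O` gives 31.7%. Compound 2 `CCC/N=C(/NC#N)NCCCCCn1nc(-c2ccccc2)ccc1=O` gives 27.5%. Compound 3 `N#CNC(=N)NCCCCCCn1nc(-c2ccccc2)ccc1=O` gives 20.5%, the lowest of the three numbers; against compound 2 the gap is within the scatter, against compound 1 it is beyond it.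

Of the measured steps, a number 4.2 percentage points lower from compound 1 to compound 2 (within the scatter) and a number 7 percentage points lower from compound 2 to compound 3 (within the scatter) both sit at the same place on the saturated chain carbon, five bonds along the chain from an aromatic nitrogen, and both stay within the scatter. Going by the values given here, the one step beyond the scatter, a number 11.2 percentage points lower from compound 1 to compound 3 (beyond the scatter), is on the amine nitrogen and is modest.

Compound 4 `CN(C)/C(=N/CCCCCn1nc(-c2ccccc2)ccc1=O)NC#N` is the next step from compound 3: a group of 8 heavy atoms (4 carbon, 4 nitrogen; no ring) in place of a group of 7 heavy atoms (3 carbon, 4 nitrogen; no ring), on a saturated chain carbon, five bonds along the chain from an aromatic nitrogen. The change occupies the same place as the two quiet chain steps, while the group entering is closer in size to that of compound 1 than to that of compound 3. Given a number 11.2 percentage points lower from compound 1 to compound 3 (beyond the scatter) read in reverse, a small rise in this assay is expected for compound 4, though it may not clear the scatter. Compound 4 is therefore estimated at 27%, between 15% and 40%, a step of a number 6.5 percentage points higher from compound 3 to compound 4 (within the scatter) from compound 3 being the expected outcome.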

Compound 4, a percentage reported as inhibition, in the whole organism at one dose (the size of the read-out at that dose, not a potency): 63.9%
Compound 4: middle estimate off by 36.9 percentage points, on the low side; the whole stated range lies below it.
By their numbers in this assay, from the lowest: compounds 3, 2 and 1 (each within the scatter of the next, the first and the last beyond it); then compound 4.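

In this assay the place on the saturated chain carbon, five bonds along the chain from an aromatic nitrogen, no longer looks quiet: the two earlier steps there stayed within the scatter, whereas compound 4 stands clear of all three other compounds, with a number 43.4 percentage points higher from compound 3 to compound 4 (beyond the scatter) and a number 36.4 percentage points higher from compound 2 to compound 4 (beyond the scatter) and also a number 32.2 percentage points higher from compound 1 to compound 4 (beyond the scatter) as its steps. Heavy-atom count does not follow this result, since the groups exchanged between compound 1 and compound 4 both hold 8 heavy atoms (4 carbon, 4 nitrogen), yet that step is large; the group entering compound 4 holds 1 hydrogen-bond donor against 3 in the group leaving compound 3, but a single compound cannot show whether that count matters. No measurement on hand accounts for the rise.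

On these data alone, whether the high number in this assay persists with a diethylamine or a longer chain at this place remains open. Also open, as far as these compounds go, is how compound 4 would read at other doses, as only a single dose stands behind these numbers.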